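Sulfonyl variation in a SUP-B15 antiproliferative series

The compounds below may be only part of what the source reports. "The series", "measured", "known", "first", "only" and "open" are said of these compounds alone.

Measured in a functional assay on SUP-B15 cells (Homo sapiens) for antiproliferative activity, with a stated time of 72 h; a higher number here means that more compound is needed for the effect, a lower number that less compound is needed:
compound 1 `COc1ccc(-c2c(Cl)c(=O)c3c(OC)cc(OC)cc3n2S(=O)(=O)c2ccc(OC)cc2)cc1` gives 17900 nM.
compound 2 `COC(=O)c1cc(=O)c2cc(N)ccc2[nH]1` gives only a limit, > 67200 nM.
compound 3 `COc1ccc(-c2cc(=O)c3c(OC)cc(OC)cc3n2S(=O)(=O)c2cccc([N+](=O)[O-])c2)cc1` gives only a limit, > 39600 nM.

Compound 3 stands at a limit rather than a number in this assay; it shares that standing with one of the other two values, as the limit of > 39600 nM in this assay, at which 1 of the 3 values shown sits, and the limit of > 67200 nM in this assay, at which 1 of the 3 values shown sits, show. Of the three compounds only compound 1 gives a measured value, and that value is weak. Among the measured compounds shown here, no pair of measured compounds differs in a single place, so no step size is known.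

Compound 4 `COc1ccc(-c2cc(=O)c3c(OC)cc(OC)cc3n2S(=O)(=O)c2ccc(C)cc2)cc1` is not yet measured. It differs from compound 3 in one place: 4-methylphenyl in place of 3-nitrophenyl on a sulfonyl sulfur. Nothing in the three values shows what this exchange does, and compound 3 gives no number to step from. The expectation is a step from compound 3 to compound 4 of an at least 1.1-fold lower number from compound 3 to compound 4 (0.05 log units; that floor lies within the scatter), that is, no change beyond the scatter and a fair chance of another limit. For compound 4 the estimated value in this assay is 35000 nM, expected to lie between 10000 nM and 90000 nM.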

Compound 4, half-maximal effective concentration: > 44800 nM
Compound 4: no number, only a limit (the forecaster's own chance of this, stated with the estimate: 50%); middle value at least 1.2-fold (0.10 log units) from the limit.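

In this assay compound 4 gives > 44800 nM as a limit. Compound 3 gives > 39600 nM as a limit too, so no step can be read between compound 3 and compound 4. As far as these compounds go, what 4-methylphenyl in place of 3-nitrophenyl on a sulfonyl sulfur does to the number remains open.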